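The source may hold more compounds than are shown below. What is called first, only, known or untested is meant among the compounds shown, and "the series" means these compounds.

In a functional assay on DU-145 cells (Homo sapiens) for inhibition (a higher number here means a weaker inhibitor, a lower number a stronger inhibitor), three compounds have been measured so far:

compound 1 `Oc1cccc(-c2cc(-c3ccccc3F)cc(-c3cccc(O)c3)n2)c1`, 11200 nM
compound 2 `Oc1ccc(-c2cc(-c3ccccc3F)cc(-c3cccc(O)c3)n2)cc1`, 3160 nM
compound 3 `Oc1ccc(-c2cc(-c3ccccc3F)cc(-c3ccc(O)cc3)n2)cc1`, 7780 nM

Compound 2 gives the lowest number of the three and is thus the strongest inhibitor among them; the step of a 3.5-fold lower number from compound 1 to compound 2 (0.55 log units; beyond the scatter) and the step of a 2.5-fold higher number from compound 2 to compound 3 (0.39 log units; beyond the scatter) both set it apart beyond the scatter. Both of these measured steps concern only where the hydroxy group sits on a phenyl ring of the shared core. Compound 4 `Oc1ccc(-c2cc(-c3ccc(C(F)(F)F)cc3)cc(-c3cccc(O)c3)n2)cc1` departs from compound 2 in a different place: 4-(trifluoromethyl)phenyl in place of 2-fluorophenyl on an aromatic carbon. Going by the values given here, neither measured step touches this part of the molecule, so no measured step bears on the change, and the data give no direction for it. With nothing to lean on, the expected step of a 1.1-fold higher number from compound 2 to compound 4 (0.04 log units; within the scatter) is taken as none beyond the scatter, and the range is left wide to reflect this. Compound 4 is therefore estimated at 3500 nM in this assay, with a range from 800 nM to 15000 nM.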

Compound 4, half-maximal inhibitory concentration: > 50000 nM
Compound 4 was reported as a limit; the forecaster's own chance of this, stated with the estimate: 10%; middle value at least 14-fold (1.15 log units) away from the limit.
By their numbers in this assay, from the lowest: compound 2; then compounds 3 and 1 (each within the scatter of the next). At a limit, above all of these: compound 4.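

In this assay, the position opposite the ring nitrogen proves far less tolerant than the hydroxy placements on the other rings, which gave only modest steps: 4-(trifluoromethyl)phenyl in place of 2-fluorophenyl gives an at least 15-fold higher number from compound 2 to compound 4 (1.19 log units; beyond the scatter). The change alters both the substituent and where it sits on that phenyl ring, and this single step cannot separate the two. Compound 4 is reported only as a limit, and the full size of the step stays unknown: the limit of > 50000 nM in this assay, at which 1 of the 4 values shown sits.

The compounds shown leave open how a plain phenyl, or a phenyl carrying a methoxy group or an amine, would behave at this position. They also leave open whether the loss would carry over to the hydroxy arrangements of compound 1 and compound 3.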